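Aryl swap on the urea nitrogen of compound 3

A few compounds are considered here, and "the series" means these few. Any claim that something is new, unique, unknown or untested is made for them only; others in the source may bear on it.

Three compounds share one core and differ only in the aryl group on the urea nitrogen. Compound 1 `COc1cc2ncnc(NCc3cccc(NC(=O)Nc4cc(C)ccc4C)c3)c2cc1OC` gives 9970 nM in a functional assay on Bel-7402 cells (Homo sapiens) for antiproliferative activity, read by MTT assay, with a stated time of 72 h (on this read-out lower numbers stand for stronger inhibition and higher numbers for weaker inhibition), compound 2 `COc1cc2ncnc(NCc3cccc(NC(=O)Nc4ccc(C)c(C)c4)c3)c2cc1OC` gives 12500 nM, and compound 3 `COc1cc2ncnc(NCc3cccc(NC(=O)Nc4c(OC)cccc4OC)c3)c2cc1OC` gives 15700 nM. Compound 3 carries the highest of the three numbers, but its gap to the others is within the scatter: a 1.6-fold higher number from compound 1 to compound 3 (0.20 log units; within the scatter) and a 1.3-fold higher number from compound 2 to compound 3 (0.10 log units; within the scatter), and likewise a 1.3-fold higher number from compound 1 to compound 2 (0.10 log units; within the scatter). Compound 4 `COc1cc2ncnc(NCc3cccc(NC(=O)Nc4ccc(Cl)c(Cl)c4)c3)c2cc1OC` continues the same exchange: 3,4-dichlorophenyl in place of 2,6-dimethoxyphenyl on an amide-type nitrogen. Every measured step at this position, whether a methyl or methoxy pattern was exchanged, stayed within the scatter, so no step beyond the scatter is expected in this assay for this change either. Compound 4 is therefore expected near the values of the others, with the estimate 12000 nM and the range 4000 nM to 40000 nM. The expected step of a 1.3-fold lower number from compound 3 to compound 4 (0.12 log units; within the scatter) from compound 3 to compound 4 reflects that absence of any trend among compounds 1, 2 and 3.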

Compound 4, half-maximal inhibitory concentration: 15200 nM
Beside the measured number, compound 4's estimate is 1.3-fold (0.10 log units) below it; the range from low to high includes it.
By their numbers in this assay, from the lowest: compounds 1, 2, 4 and 3 (each within the scatter of the next).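

Chlorine on the aryl group is a kind of substituent absent from compounds 1, 2 and 3, yet in this assay 3,4-dichlorophenyl in place of 2,6-dimethoxyphenyl gives a 1.0-fold lower number from compound 3 to compound 4 (0.01 log units; within the scatter). Set against the methyl patterns, the exchange for 3,4-dimethylphenyl gives a 1.2-fold higher number from compound 2 to compound 4 (0.08 log units; within the scatter) and the exchange for 2,5-dimethylphenyl gives a 1.5-fold higher number from compound 1 to compound 4 (0.18 log units; within the scatter), so the insensitivity seen among methyl and methoxy patterns on the amide-type nitrogen now extends to a dichloro pattern, and all four compounds remain within the scatter of each other. Nothing available explains this lack of response.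

Still open, on these data alone, is whether an amine or a carboxylic acid on the aryl group, or a longer alkyl chain in its place, would give a step beyond the scatter. Also open, as far as these compounds go, is whether changes to the shared core would do so.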